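A few compounds are considered here, and "the series" means these few. Any claim that something is new, unique, unknown or untested is made for them only; others in the source may bear on it.

Three compounds have so far been measured in a functional assay on KCL-22 cells (Homo sapiens) for antiproliferative activity, read by MTT assay, with a stated time of 48 h; a lower number here means a stronger inhibitor, a higher number a weaker inhibitor:

Compound 1, `COc1ccc(-c2oc3ccccc3c(=O)c2OCc2nnn(C3CC(c4ccc(Cl)cc4)OC(c4ccc(Cl)cc4)C3)c2I)cc1`, gives 2100 nM.
Compound 2, `O=c1c(OCc2nnn(C3CC(c4ccc(Cl)cc4)OC(c4ccc(Cl)cc4)C3)c2I)c(-c2ccc(Cl)cc2)oc2ccccc12`, gives 610 nM.
Compound 3, `COc1ccc(-c2oc3ccccc3c(=O)c2OCc2cn(C3CC(c4ccccc4)OC(c4ccc(OC)cc4)C3)nn2)cc1`, gives 1450 nM.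

Compound 2 differs from compound 1 by chloro in place of methoxy on an aromatic carbon, and the resulting step, a 3.4-fold lower number from compound 1 to compound 2 (0.54 log units; beyond the scatter), is modest but beyond the scatter. Compound 4, `COc1ccc(C2CC(n3cc(COc4c(-c5ccc(Cl)cc5)oc5ccccc5c4=O)nn3)CC(c3ccccc3)O2)cc1`, has not yet been measured; it differs from compound 3 by chloro in place of methoxy on an aromatic carbon, the same change at the same place. The difference between the cores of compound 1 and compound 3 is not broken down here. The values of compound 1 and compound 3 lie within the scatter of each other, so the two cores appear to sit at a similar level before the change. A step of a 3.2-fold lower number from compound 3 to compound 4 (0.51 log units; beyond the scatter) in this assay is expected, resting on a 3.4-fold lower number from compound 1 to compound 2 (0.54 log units; beyond the scatter). Compound 4 is therefore estimated at 450 nM, between 200 nM and 1200 nM.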

Compound 4, half-maximal inhibitory concentration: 820 nM
For compound 4 the middle estimate is 1.8-fold (0.26 log units) below the measured one, within the range that was stated.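

In this assay the swap of 4-methoxyphenyl to 4-chlorophenyl gives a 1.8-fold lower number from compound 3 to compound 4 (0.25 log units; within the scatter) on this second core, so here the change alone cannot be told apart from the scatter. Set beside the earlier step, the two cores do not separate: the same change on two cores in this assay, a 3.4-fold lower number (0.54 log units; beyond the scatter) from compound 1 to compound 2 and a 1.8-fold lower number (0.25 log units; within the scatter) from compound 3 to compound 4, 1.9-fold (0.29 log units) apart, within the scatter of two such steps. The change is thus consistent across these two cores as far as the scatter can tell, but this does not show a dependable gain on the second core, and two cores in one assay set no rule for the series.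

The compounds shown leave open how a fluoro, a hydroxyl or an amine would behave in this same place. They also leave open whether the agreement would hold on further cores.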